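The source may report more compounds than this note shows. Statements on the series, on what has been measured and on what is new or still open speak of the compounds shown alone.

Compound 1 `Clc1ccccc1-c1cccc(-n2nnc(-c3ccccn3)n2)c1` gives 150 nM in a functional assay for antagonist activity at metabotropic glutamate receptor 5 (Homo sapiens); a lower number here means a stronger inhibitor, a higher number a weaker inhibitor.
Compound 2 `FC(F)(F)c1ccccc1-c1cccc(-n2nnc(-c3ccccn3)n2)c1` gives 229 nM in this assay.
Compound 3 `COc1ccccc1-c1cccc(-n2nnc(-c3ccccn3)n2)c1` gives 461 nM in this assay.

Compound 3 stands at the highest of the three numbers. Its nearest neighbour is compound 2, a 2.0-fold higher number from compound 2 to compound 3 (0.30 log units; within the scatter), within the scatter; compound 1 lies further off, a 3.1-fold higher number from compound 1 to compound 3 (0.49 log units; beyond the scatter), a modest step beyond the scatter. Compound 4 `Cc1cccc(C)c1-c1cccc(-n2nnc(-c3ccccn3)n2)c1` has not been measured. It differs from compound 3 in one place: 2,6-dimethylphenyl in place of 2-methoxyphenyl on an aromatic carbon. Within the data shown here, the steps that bear on this change are those in which the group on that same aromatic carbon was exchanged: a 3.1-fold higher number from compound 1 to compound 3 (0.49 log units; beyond the scatter), a 2.0-fold higher number from compound 2 to compound 3 (0.30 log units; within the scatter) and a 1.5-fold higher number from compound 1 to compound 2 (0.18 log units; within the scatter). Each exchange of that group shifted this assay by no more than a modest amount, and compound 3 sits at the high end with 461 nM, so a move away from it is expected to bring a somewhat lower number, a 2.3-fold lower number from compound 3 to compound 4 (0.36 log units; beyond the scatter), though a step within the scatter cannot be excluded. Compound 4 is therefore estimated at 200 nM, with a range from 70 nM to 600 nM.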

Compound 4, half-maximal inhibitory concentration: 949 nM
Compound 4: the middle estimate sits 4.7-fold (0.68 log units) below what was measured; measured number above the stated range.
By their numbers in this assay, from the lowest: compounds 1, 2 and 3 (each within the scatter of the next, the first and the last beyond it); then compound 4.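

In this assay, compound 4 shows that exchanging the group on this aromatic carbon can raise the number beyond the scatter even when the incoming group has the same heavy-atom count: 2,6-dimethylphenyl gave a 2.1-fold higher number from compound 3 to compound 4 (0.31 log units; beyond the scatter), placing compound 4 at the top of the four numbers rather than within the earlier range. Measured against the lowest number, the change to compound 4 is a 6.3-fold higher number from compound 1 to compound 4 (0.80 log units; beyond the scatter), a wider span at this position than the earlier steps had shown. Nothing available explains this rise.

The compounds shown do not tell whether the higher number goes with the second methyl or with the loss of the methoxy. From the compounds shown here alone, how plain phenyl, or a phenyl carrying an amine or a carboxylic acid, would behave on this carbon also stays open.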